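The source may hold more compounds than are shown below. What is called first, only, known or untested is meant among the compounds shown, and "the series" means these compounds.

Series notes, cytotoxicity branch. Three compounds have been run in an ADME assay on NIH3T3 cells (Mus musculus) for cytotoxicity, read by MTT assay, with a stated time of 24 h (a higher number here means a weaker inhibitor, a lower number a stronger inhibitor), so far. Compound 1 `Cc1cc(-c2nc3cc(F)ccc3o2)ccc1NC(=O)CCl` gives 10500 nM. Compound 3 `Cc1cc(-c2nc3ccccc3o2)ccc1NC(=O)CCl`, the same chloroacetamide without the fluorine, gives 12200 nM. Compound 2 `Cc1cc(-c2nc3ccccc3o2)ccc1NC(=O)CN1CCN(CCCN(C)C)CC1`, carrying the piperazine side chain with the dimethylaminopropyl arm in place of the chloroacetamide, gives 33500 nM and stands highest of the three; its nearest neighbour is compound 3 and its furthest is compound 1, both gaps lying beyond the scatter.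

Among the compounds with values here, the one matched step so far is a 1.2-fold lower number from compound 3 to compound 1 (0.07 log units; within the scatter), the change being (fluoro in place of hydrogen on an aromatic carbon). The difference between the cores of compound 2 and compound 3 is not broken down here.

Compound 4 `Cc1cc(-c2nc3cc(F)ccc3o2)ccc1NC(=O)CN1CCN(CCCN(C)C)CC1` has not yet been measured in this assay. It differs from compound 2 by fluoro in place of hydrogen on an aromatic carbon, which is the same kind of change as that from compound 3 to compound 1, and the surroundings of the place are described in the same words in both cases. Within the data shown here, for compound 4 the step from compound 2 is expected to be a 1.1-fold lower number from compound 2 to compound 4 (0.05 log units; within the scatter), resting on the single earlier fluoro step from compound 3 to compound 1 being within the scatter. Compound 4 is therefore estimated at 30000 nM, with a range from 15000 nM to 60000 nM.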

Compound 4, half-maximal inhibitory concentration: 65700 nM
For compound 4 the middle estimate is 2.2-fold (0.34 log units) below the measured one, and the stated range ends below it.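

In this assay, 1,3-benzoxazol-2-yl going to 5-fluoro-1,3-benzoxazol-2-yl on the core of compound 2 gives a 2.0-fold higher number from compound 2 to compound 4 (0.29 log units; within the scatter), so on this core, as on the chloroacetamide core, the step stays inside the usual spread of repeat measurements. Set side by side, the two steps do not separate the cores: the same change on two cores in this assay, a 1.2-fold lower number (0.07 log units; within the scatter) from compound 3 to compound 1 and a 2.0-fold higher number (0.29 log units; within the scatter) from compound 2 to compound 4, 2.3-fold (0.36 log units) apart, within the scatter of two such steps

In this assay, then, fluoro in place of hydrogen at this place can be carried between the chloroacetamide and the piperazine side chain with no readable effect on the number, but this rests on two matched pairs only and does not show that the step is truly nil or identical on both cores, nor how it would behave on any other core or in any other assay.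

The compounds shown carry a single substituent at a single place on the six-membered aromatic ring, so it remains open whether chloro, methoxy or a nitrile there, or fluoro elsewhere on that ring, would give a step beyond the scatter. Also open, on these data alone, is how the same change would read on a core with a carboxylic acid or a longer chain in place of the dimethylaminopropyl arm.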